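A few compounds are considered here, and "the series" means these few. Any claim that something is new, unique, unknown or untested is made for them only; others in the source may bear on it.

In a functional assay on C6 cells (Rattus norvegicus) for cytotoxicity, read by MTT assay, with a stated time of 24 h (a higher number here means a weaker inhibitor, a lower number a stronger inhibitor), compound 2 `COc1ccc(-c2cs/c(=N/NC(=O)CSc3nnc(C)s3)n2-c2ccccc2)cc1` gives 18.7 ug/mL. Compound 1 `Cc1nnc(SCC(=O)N/N=c2/scc(-c3ccc(F)cc3)n2-c2ccccc2)s1` carries one change against compound 2: fluoro in place of methoxy on an aromatic carbon. This change made a 1.5-fold higher number from compound 2 to compound 1 (0.16 log units; within the scatter), so that compound 1, giving 27.3 ug/mL, cannot be told apart from compound 2 on this read-out. Compound 3 `COc1ccc(-c2cs/c(=N/NC(=O)CSc3ncccn3)n2-c2ccccc2)cc1` differs from compound 2 in the core: pyrimidin-2-yl in place of 5-methyl-1,3,4-thiadiazol-2-yl on a sulfur. Here the step was a 5.5-fold higher number from compound 2 to compound 3 (0.74 log units; beyond the scatter), and compound 3 gives 102 ug/mL in this assay, the highest of the three numbers.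

Compound 4 `O=C(CSc1ncccn1)N/N=c1/scc(-c2ccc(F)cc2)n1-c1ccccc1` has not yet been measured. It stands to compound 3 as compound 1 stands to compound 2: fluoro in place of methoxy on an aromatic carbon. The surroundings of the exchange read the same in both pairs, so this is the same change, now made on the core of compound 3 rather than on the core of compound 2. Among the measured compounds shown here, the only measured instance of this change is the step from compound 2 to compound 1, which stayed within the usual scatter.

For the measured compounds named here, compound 4 is therefore expected to sit close to compound 3, with an expected step of a 1.4-fold higher number from compound 3 to compound 4 (0.14 log units; within the scatter), resting on the single earlier instance in compound 1, a 1.5-fold higher number from compound 2 to compound 1 (0.16 log units; within the scatter). Whether the same change behaves alike on the second core is not shown by any measured pair. The estimate for compound 4 in this assay is 140 ug/mL, with a likely range from 70 ug/mL to 280 ug/mL.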

Compound 4, half-maximal inhibitory concentration: 110 ug/mL
The estimate for compound 4 lay 1.3-fold (0.10 log units) above the measured number; measured number inside the range.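

In this assay, the exchange of methoxy for fluoro on the core of compound 3 gave a 1.1-fold higher number from compound 3 to compound 4 (0.03 log units; within the scatter), and this step agrees with the earlier instance: the same change on two cores in this assay, a 1.5-fold higher number (0.16 log units; within the scatter) from compound 2 to compound 1 and a 1.1-fold higher number (0.03 log units; within the scatter) from compound 3 to compound 4, 1.4-fold (0.13 log units) apart, within the scatter of two such steps. The exchange of 5-methyl-1,3,4-thiadiazol-2-yl for pyrimidin-2-yl on the sulfur, now read on the fluoro-bearing pair, gave a 4.0-fold higher number from compound 1 to compound 4 (0.61 log units; beyond the scatter), and this too agrees with its earlier instance: the same change on two cores in this assay, a 5.5-fold higher number (0.74 log units; beyond the scatter) from compound 2 to compound 3 and a 4.0-fold higher number (0.61 log units; beyond the scatter) from compound 1 to compound 4, 1.4-fold (0.13 log units) apart, within the scatter of two such steps. Within these four compounds, each change therefore carried from one core to the other with its size preserved within the scatter, but this rests on only two cores per change in this one assay, and it does not show that either change would behave alike on any further core or that any other exchange would carry over in the same way.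

From the compounds shown here alone, what a chloro, an amine or a carboxylic acid in place of the methoxy would do on either core remains open. So does whether an amine or a longer chain in place of the pyrimidin-2-yl on the sulfur would give a step of similar size to the one seen here.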